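Cyclopropyl for Phenyl on the Lactam Nitrogen: Antiproliferative Outcome

A few compounds are considered here, and "the series" means these few. Any claim that something is new, unique, unknown or untested is made for them only; others in the source may bear on it.

Measured compounds:
compound 1, `COc1ncc(-c2ccc3c(c2)N(c2ccccc2)C(=O)CO3)cc1NS(=O)(=O)c1ccc(F)cc1`, 15200 nM
compound 2, `O=C1COc2ccc(-c3cccc(NS(=O)(=O)c4ccc(F)cc4)c3)cc2N1c1ccccc1`, > 40000 nM
compound 3, `COc1ncc(-c2ccc3c(c2)N(C2CC2)C(=O)CO3)cc1NS(=O)(=O)c1ccc(F)cc1`, 23900 nM

Of the compounds shown here, three have been measured in a functional assay on A-375 cells (Homo sapiens) for antiproliferative activity, read by MTT assay, with a stated time of 72 h; on this read-out higher numbers stand for weaker inhibition and lower numbers for stronger inhibition. Compound 1 has the structure `COc1ncc(-c2ccc3c(c2)N(c2ccccc2)C(=O)CO3)cc1NS(=O)(=O)c1ccc(F)cc1` and in this assay compound 1 gives 15200 nM. Compound 3, `COc1ncc(-c2ccc3c(c2)N(C2CC2)C(=O)CO3)cc1NS(=O)(=O)c1ccc(F)cc1`, carries the change cyclopropyl in place of phenyl on an amide-type nitrogen in a ring relative to compound 1, and in this assay compound 3 gives 23900 nM. The step of a 1.6-fold higher number from compound 1 to compound 3 (0.20 log units; within the scatter) is therefore small.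

Compound 2 has the structure `O=C1COc2ccc(-c3cccc(NS(=O)(=O)c4ccc(F)cc4)c3)cc2N1c1ccccc1`. In this assay compound 2 reaches only the limit of the assay, > 40000 nM, so no number is known for it; this is the single case of the limit of > 40000 nM in this assay, at which 1 of the 3 values shown sits. The difference between the core of compound 2 and the core of compound 1 is not broken down here.

Compound 4, `O=C1COc2ccc(-c3cccc(NS(=O)(=O)c4ccc(F)cc4)c3)cc2N1C1CC1`, is not yet measured. It differs from compound 2 by cyclopropyl in place of phenyl on an amide-type nitrogen in a ring, the same change that takes compound 1 to compound 3.

Because the same change gave a 1.6-fold higher number from compound 1 to compound 3 (0.20 log units; within the scatter), the step for compound 4 is expected to be similarly small, namely a step that the limit leaves unreadable from compound 2 to compound 4. Since compound 2 already sits at the limit, compound 4 is expected to give 60000 nM, most likely between 30000 nM and 150000 nM, and it is likely that this assay will again report only a limit for compound 4.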

Compound 4, half-maximal inhibitory concentration: > 40000 nM
Compound 4 was reported as a limit; the forecaster's own chance of this, stated with the estimate: 80%; the middle value is on the limit's open side.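

In this assay compound 2 and compound 4 both stand at a limit and not at a number, so no step can be read between them: the limit of > 40000 nM in this assay, at which 2 of the 4 values shown sit.

The compounds shown leave open what cyclopropyl in place of phenyl does on the core of compound 2, and whether its size there matches the small step seen on the core of compound 1.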